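This account rests on a few compounds, and the source may have more. Where it says the series, first, only, none or still open, it means among the compounds named here.

Compounds measured so far:

Compound 1, `CS(=O)(=O)OCC1CN(S(C)(=O)=O)c2cc(OCc3ccccc3)ccc21`: 4.39 ug/mL
Compound 2, `CS(=O)(=O)OCC1CN(S(C)(=O)=O)c2cc(O)c([N+](=O)[O-])cc21`: 0.764 ug/mL
Compound 3, `CS(=O)(=O)OCC1CN(S(C)(=O)=O)c2cc(OCc3ccccc3)c(Br)cc21`: 5.21 ug/mL

In a functional assay on KB cells (Homo sapiens), read by crystal violet staining (a higher number here means a weaker inhibitor, a lower number a stronger inhibitor), compound 3 gives the highest of the three numbers. Its nearest neighbour is compound 1, from which it differs only by bromo in place of hydrogen on an aromatic carbon; the step of a 1.2-fold higher number from compound 1 to compound 3 (0.07 log units; within the scatter) is within the scatter, so the two cannot be ordered. Compound 2, which carries a nitro group and a free hydroxyl instead of the benzyloxy group, gives 0.764 ug/mL, a number well apart from compound 3.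

Compound 4, `CS(=O)(=O)OCC1CN(S(C)(=O)=O)c2cc(OCc3ccccc3)c([N+](=O)[O-])cc21`, has not yet been measured. It differs from compound 3 by nitro in place of bromo on an aromatic carbon, with the benzyloxy group kept. Going by the values given here, the only single-step change among the measured compounds, from compound 1 to compound 3, touches the same aromatic carbon and was flat. Among the compounds with values here, no measured step isolates the nitro group alone, since compound 2 changes two places at once relative to compound 4. The author therefore expects in this assay a step for compound 4 that is small and, if anything, toward a lower number, a 1.5-fold lower number from compound 3 to compound 4 (0.17 log units; within the scatter). The estimated value for compound 4 is 3.5 ug/mL, with a range from 1.2 ug/mL to 9 ug/mL.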

Compound 4, half-maximal inhibitory concentration: 7.91 ug/mL
For compound 4 the middle estimate is 2.3-fold (0.35 log units) below the measured one; measured number inside the range.
By their numbers in this assay, from the lowest: compound 2; then compounds 1, 3 and 4 (each within the scatter of the next).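

In this assay, with the benzyloxy group kept, the aromatic carbon para to a fused ring has now held hydrogen, bromo and nitro without any of them separating from the others: the exchange of bromo for nitro gives a 1.5-fold higher number from compound 3 to compound 4 (0.18 log units; within the scatter) and the exchange of hydrogen for nitro gives a 1.8-fold higher number from compound 1 to compound 4 (0.26 log units; within the scatter) so both steps join the earlier bromo step within the scatter. Going by these compounds alone, the oxygen on the aromatic ring behaves differently, and with the nitro group held fixed, benzyl in place of hydrogen gives a 10-fold higher number from compound 2 to compound 4 (1.02 log units; beyond the scatter) which is the first single-place step beyond the scatter in this set. Among these compounds, then, the larger change is tied to the group on that oxygen and not to the group on the aromatic carbon.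

The compounds shown leave open whether a free hydroxyl also gives a lower number when bromo or hydrogen stands on the aromatic carbon in place of nitro. They also leave open how a methyl ether on that oxygen, or an amine on the aromatic carbon, would compare.

Nothing shown here offers an explanation for these results.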